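Swapping Chloro for Thiophen-3-yl: an Expected Small Shift

A few compounds are considered here, and "the series" means these few. Any claim that something is new, unique, unknown or untested is made for them only; others in the source may bear on it.

Measured compounds:
Compound 1 `CCCS(=O)(=O)c1cccc(C#Cc2c(Cl)cccc2OCC(=O)O)c1` gives 55 nM in an assay on CHO cells for displacement of a labelled ligand from prostaglandin D2 receptor 2 (Homo sapiens), read by scintillation counting; a lower number here means a stronger inhibitor, a higher number a weaker inhibitor
Compound 2 `Cn1ccnc1C#Cc1cc(Cl)ccc1OCC(=O)O` gives 1470 nM in this assay
Compound 3 `CCCS(=O)(=O)c1ccc(C)c(C#Cc2cc(Cl)ccc2OC(CC(C)C)C(=O)O)c1` gives 515 nM in this assay

Of the three compounds measured, compound 1 has the lowest number in this assay, and both other values lie beyond the scatter of the method, so compound 1 is the strongest inhibitor of this small set. Compound 3 comes nearest, and compound 2 lies furthest away.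

Compound 4 `CCCS(=O)(=O)c1cccc(C#Cc2c(OCC(=O)O)cccc2-c2ccsc2)c1` has not yet been measured. It differs from compound 1 in a single place: thiophen-3-yl in place of chloro on an aromatic carbon. In words, a thiophen-3-yl ring takes the place of the chloro on the aromatic carbon, ortho to a large group and meta to the carboxymethoxy group.

For the measured compounds named here, no pair of measured compounds differs in exactly this way, so there is no directly comparable step to lean on. The change exchanges a single atom for a small aromatic ring at the same position; such a swap could be tolerated or could cost some affinity. The step from compound 1 to compound 4 in this assay is expected to be a 2.2-fold higher number from compound 1 to compound 4 (0.34 log units; beyond the scatter), a modest weakening that may still fall within the scatter. Compound 4 is therefore estimated at 120 nM, with a plausible range from 30 nM to 500 nM.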

Compound 4, inhibition constant: 18 nM
Compound 4: the middle estimate sits 6.7-fold (0.82 log units) above what was measured; measured number outside the range, below it.
By their numbers in this assay, from the lowest: compound 4; then compound 1; then compound 3; then compound 2.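

This one step shows that the position tolerates far more than a single atom. In this assay, replacing the chloro with thiophen-3-yl gives a 3.1-fold lower number from compound 1 to compound 4 (0.49 log units; beyond the scatter), so inhibition becomes stronger, not weaker, as one chlorine atom gives way to a five-membered aromatic ring of 5 heavy atoms. The earlier compounds could not show this, since no two of them differ in one place, and the data shown offer no explanation for the gain.

As far as these compounds go, what remains open is whether the gain is specific to thiophen-3-yl or would also appear with other groups on this aromatic carbon, such as a phenyl ring, a thiophen-2-yl ring, a methyl group or an amine. For the compounds shown here, with only this single step at the position, it is also unknown whether the same swap would lower the number to a similar extent on a different core.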